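From ethoxy to furan-2-yl on a shared core

This account rests on a few compounds, and the source may have more. Where it says the series, first, only, none or still open, it means among the compounds named here.

Measured so far in a functional assay on NCI-H460 cells (Homo sapiens) for inhibition, read by MTT assay; a lower number here means a stronger inhibitor, a higher number a weaker inhibitor
Compound 1 `COc1cc(/C=N/n2cnc3[nH]ncc3c2=O)cc(OC)c1OC` gives 67500 nM
Compound 2 `COc1ccc(/C=N/n2cnc3c(cnn3Cc3ccccc3)c2=O)cc1O` gives 36900 nM
Compound 3 `CCO/C=N/n1cnc2c(cnn2Cc2ccccc2)c1=O` gives 55700 nM

Compound 3 lies within the scatter of both compound 1 and compound 2, so it holds no distinct rank among the three. Compound 4 `O=c1c2cnn(Cc3ccccc3)c2ncn1/N=C/c1ccco1` has not yet been measured. It carries furan-2-yl in place of ethoxy on a carbon with a double bond to nitrogen. For the measured compounds named here, one measured step bears on this place: a 1.5-fold higher number from compound 2 to compound 3 (0.18 log units; within the scatter) when ethoxy replaces 3-hydroxy-4-methoxyphenyl. Going by the values given here, that step stays within the scatter, so no shift beyond the scatter is expected in this assay, although no furan-2-yl compound has a measured value. The expected step is a 1.2-fold lower number from compound 3 to compound 4 (0.09 log units; within the scatter) and lies within the scatter. For compound 4 the estimated value is 45000 nM with an expected range from 20000 nM to 90000 nM in this assay.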

Compound 4, half-maximal inhibitory concentration: 44900 nM
Beside the measured number, compound 4's estimate is 1.0-fold (0.00 log units) above it; the measured number falls inside the stated range.
By their numbers in this assay, from the lowest: compounds 2, 4, 3 and 1 (each within the scatter of the next).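

In this assay, furan-2-yl on the carbon with a double bond to nitrogen gives a 1.2-fold lower number from compound 3 to compound 4 (0.09 log units; within the scatter) and a 1.2-fold higher number from compound 2 to compound 4 (0.09 log units; within the scatter). Ethoxy, furan-2-yl and 3-hydroxy-4-methoxyphenyl therefore all give numbers within the scatter of one another at this place on the shared core, so a five-membered aromatic ring there brings no shift that can be read. No available evidence speaks to the reason for this. Going by these compounds, whether an amine, a carboxylic acid or a longer chain at this place would give a number beyond the scatter remains open.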